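A Chlorophenyl Swap on a Shared Core

The compounds below may be only part of what the source reports. "The series", "measured", "known", "first", "only" and "open" are said of these compounds alone.

Of the compounds shown here, three built on one shared core have been measured. Compound 1 `CCCSc1nc(N/N=C(\C)c2ccccc2O)c2nnn(Cc3ccco3)c2n1` in a functional assay on MCF7 cells (Homo sapiens) for antiproliferative activity, read by MTT assay, with a stated time of 72 h (a higher number here means a weaker inhibitor, a lower number a stronger inhibitor), gives 29000 nM. Compound 2 `CCCSc1nc(N/N=C/c2ccccc2Cl)c2nnn(Cc3ccccc3)c2n1` gives 13800 nM in this assay. Compound 3 `CCCSc1nc(N/N=C/c2cc(OC)c(OC)c(OC)c2)c2nnn(Cc3ccccc3)c2n1` reaches only a limit of the assay in this assay, reported as > 64000 nM; this is the limit of > 64000 nM in this assay, at which 1 of the 3 values shown sits.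

Among the two numbers given, compound 2 stands lowest, and compound 1 sits at a number higher by a margin beyond the usual scatter. The two differ in more than one place, so the values are simply what they show.

Compound 4 `CCCSc1nc(N/N=C/c2ccc(Cl)cc2)c2nnn(Cc3ccccc3)c2n1` has not yet been measured. It differs from compound 2 by 4-chlorophenyl in place of 2-chlorophenyl on a carbon with a double bond to nitrogen. Among the measured compounds shown here, no pair of measured compounds differs in this single way, so nothing here sets the size of such a step. Compound 4 is expected to land close to compound 2, with a step of a 1.2-fold higher number from compound 2 to compound 4 (0.06 log units; within the scatter) that does not clearly exceed the scatter, leaning if anything toward a slightly higher number. The value of compound 4 in this assay is estimated at 16000 nM, within 6000 nM to 45000 nM.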

Compound 4, half-maximal inhibitory concentration: > 64000 nM
Compound 4 was reported as a limit (the forecaster's own chance of this, stated with the estimate: 10%); middle value at least 4.0-fold (0.60 log units) from the limit.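

With the same atoms joined differently, 4-chlorophenyl in place of 2-chlorophenyl on a carbon with a double bond to nitrogen gives, in this assay, an at least 4.6-fold higher number from compound 2 to compound 4 (0.66 log units; beyond the scatter). Among the compounds shown here, the earlier compounds differed in more than one place, so this pair is the first to show that a single change on the shared core matters, and that the placing of the chlorine on the phenyl ring alone is enough to produce it. The value of compound 4 is a limit of the assay and not a number, so the step has a lower bound but no upper one, and this limit is shared with compound 3: the limit of > 64000 nM in this assay, at which 2 of the 4 values shown sit.

The compounds shown leave open how a bromophenyl or an aminophenyl group would fare at this place. They also leave open whether the same step would appear with a longer chain on the sulfur of the shared core.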